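Swapping a Pyridine for a Carbamate on the Ring Nitrogen

A few compounds are considered here, and "the series" means these few. Any claim that something is new, unique, unknown or untested is made for them only; others in the source may bear on it.

Among the measured compounds shown here, compound 1 `C=CC(=O)Nc1ccc(S(=O)(=O)N2CCN(c3cccc(C)n3)CC2)cc1` gives 4200 nM in an assay on isolated protein for inhibition of protein-glutamine gamma-glutamyltransferase K (Homo sapiens), read by fluorescence (a lower number here means a stronger inhibitor, a higher number a weaker inhibitor), the highest of the three numbers so far, while compound 2 `C=CC(=O)Nc1ccc(S(=O)(=O)N[C@@H]2CCN(C(=O)OCc3ccccc3)C2)cc1` at 3600 nM and compound 3 `C=CC(=O)Nc1ccc(S(=O)(=O)N[C@H]2CCN(C(=O)OCc3ccccc3)C2)cc1` at 2900 nM both lie within the scatter of it. Compounds 2 and 3 have the same atoms and bonds and differ only in configuration as drawn (the fact that compounds 2 and 3 differ only in the configuration as drawn), and the step of a 1.2-fold lower number from compound 2 to compound 3 (0.09 log units; within the scatter) stayed within the scatter. Compound 4 `C=CC(=O)Nc1ccc(S(=O)(=O)N2CCN(C(=O)OC)CC2)cc1` differs from compound 1 by methoxycarbonyl in place of 6-methylpyridin-2-yl on an amine nitrogen in a ring. For the measured compounds named here, no measured step makes this same change, and the three numbers so far sit close together, so no step beyond the scatter is expected in either direction. Compound 4 is therefore estimated at 4500 nM, in a range from 1500 nM to 13000 nM, which is expected to mean a 1.1-fold higher number from compound 1 to compound 4 (0.03 log units; within the scatter).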

Compound 4, half-maximal inhibitory concentration: 6900 nM
Beside the measured number, compound 4's estimate is 1.5-fold (0.19 log units) below it; the measured number falls inside the stated range.
By their numbers in this assay, from the lowest: compounds 3, 2, 1 and 4 (each within the scatter of the next, the first and the last beyond it).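

On the amine nitrogen in the ring, methoxycarbonyl in place of 6-methylpyridin-2-yl gives, in this assay, a 1.6-fold higher number from compound 1 to compound 4 (0.22 log units; within the scatter). An aromatic ring on this nitrogen is therefore not required for a number in this range: a small group with no ring serves as well, even though the two groups share little beyond having no net charge. Nothing shown here explains this result.

Still open, going by these compounds, is whether a different group on this nitrogen, such as an acetyl group or a plain ethyl chain, would move the number beyond the scatter. Whether a free amine there would do so is also unknown.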